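Working notes: carboxy to hydroxycarbamoyl, cytotoxicity read-out

The source may report more compounds than this note shows. Statements on the series, on what has been measured and on what is new or still open speak of the compounds shown alone.

Measured so far:
compound 1 `O=C(NO)C1CCC2(CC1)OOC1(OO2)C2CC3CC(C2)CC1C3` — > 50000 nM
compound 2 `O=C(O)[C@H]1CC[C@]2(CC1)OO[C@]1(O2)C2CC3CC(C2)CC1C3` — > 100000 nM

In an ADME assay on L02 cells (Homo sapiens) for cytotoxicity, read by MTT assay, with a stated time of 48 h (on this read-out higher numbers stand for weaker inhibition and lower numbers for stronger inhibition), compound 2 gives > 100000 nM, which is a limit of the assay and not a number. Compound 1 gives > 50000 nM in this assay, again only a limit. Going by the values given here, compound 2 therefore stands at the limit of > 100000 nM in this assay, at which 1 of the 2 values shown sits, and the only other value available sits at the limit of > 50000 nM in this assay, at which 1 of the 2 values shown sits, so no measured step between compounds differing in one place exists in this set.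

Compound 3 `O=C(NO)[C@H]1CC[C@]2(CC1)OO[C@]1(O2)C2CC3CC(C2)CC1C3` differs from compound 2 by hydroxyamino in place of hydroxy on a carbonyl carbon. Compound 1 carries the same hydroxycarbamoyl group on the shared core, without stated stereochemistry, and gives only a limit in this assay. On that basis the step from compound 2 to compound 3 is expected to be an at least 1.2-fold lower number from compound 2 to compound 3 (0.09 log units; that floor lies within the scatter), that is, no change beyond the scatter in either direction. Compound 3 is estimated at 80000 nM in this assay, with a range from 30000 nM to 200000 nM, and most likely reported again only as a limit.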

Compound 3, half-maximal inhibitory concentration: > 50000 nM
Compound 3: only a limit was reported (the forecaster's own chance of this, stated with the estimate: 80%); the middle value is on the limit's open side.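

In this assay compound 3 gives > 50000 nM, a limit of the assay and not a number. Compound 2 gives > 100000 nM, also a limit, and no step can be read between compound 2 and compound 3. The compounds shown leave open whether hydroxyamino in place of hydroxy on a carbonyl carbon changes this read-out in either direction.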